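Swapping Ethyl for 3-Fluorobenzyl: An Expected Gain

The compounds below may be only part of what the source reports. "The series", "measured", "known", "first", "only" and "open" are said of these compounds alone.

Among the measured compounds shown here, compound 2 `CCCCC#Cc1nc(NCC)c2ncn([C@H]3[C@H](O)[C@H](O)[C@@H]4C[C@@H]43)c2n1` has the highest of the two numbers measured so far in an assay on RBL-2H3 cells for displacement of a labelled ligand from adenosine receptor A3 (Rattus norvegicus), with a stated time of 60 min (on this read-out lower numbers stand for stronger inhibition and higher numbers for weaker inhibition), where compound 2 gives 176 nM. Its nearest neighbour is compound 1 `CCCCC#Cc1nc(NCc2cccc(Br)c2)c2ncn([C@H]3[C@H](O)[C@H](O)[C@@H]4C[C@@H]43)c2n1`, which in this assay gives 59 nM. For the measured compounds named here, the only measured step, a 3.0-fold higher number from compound 1 to compound 2 (0.47 log units; beyond the scatter), replaced a bromine-bearing benzyl group with ethyl and gave a higher number. Compound 3 `CCCCC#Cc1nc(NCc2cccc(F)c2)c2ncn([C@H]3[C@H](O)[C@H](O)[C@@H]4C[C@@H]43)c2n1` differs from compound 2 by 3-fluorophenyl in place of methyl on a saturated chain carbon bound to a nitrogen on an aromatic ring. This change runs opposite to the measured step, with fluorine rather than bromine on the ring, so the bearing step is a 3.0-fold higher number from compound 1 to compound 2 (0.47 log units; beyond the scatter) read in reverse. A lower number for compound 3 than for compound 2 is therefore expected, of about the same size, landing near compound 1. Compound 3 is expected to give 70 nM in this assay, within 25 nM to 200 nM. For compound 3 this amounts to an expected step of a 2.5-fold lower number from compound 2 to compound 3 (0.40 log units; beyond the scatter).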

Compound 3, inhibition constant: 43 nM
Beside the measured number, compound 3's estimate is 1.6-fold (0.21 log units) above it; low and high end bracket the measured number.
By their numbers in this assay, from the lowest: compounds 3 and 1 (each within the scatter of the next); then compound 2.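

In this assay, the lower number seen with a halogen-bearing benzyl group rather than ethyl now holds for a second halogen, with a 4.1-fold lower number from compound 2 to compound 3 (0.61 log units; beyond the scatter), a step in the opposite direction to a 3.0-fold higher number from compound 1 to compound 2 (0.47 log units; beyond the scatter). Exchanging the halogen on the ring, the one place where the two benzyl compounds differ, gives a 1.4-fold lower number from compound 1 to compound 3 (0.14 log units; within the scatter), so the two halogens cannot be told apart in this read-out. No evidence on the reason for these differences is at hand. The compounds shown leave open whether an unsubstituted benzyl group, or a methoxy group or carboxylic acid in place of the halogen, would keep the lower number. They also leave open whether a longer chain such as butyl, with no aromatic ring, would do the same as the benzyl groups.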